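This account rests on a few compounds, and the source may have more. Where it says the series, first, only, none or still open, it means among the compounds named here.

Two pairs of compounds are compared here, each pair sharing a core and differing only in the aryl group on an amide-type nitrogen. Compound 1 `CC(=O)Nc1n[nH]c2cc(-c3cn([C@@H]4CN[C@H](C(=O)Nc5ccc(Cl)cc5Cl)C4)nn3)ccc12` in a functional assay on K562 cells (Homo sapiens) for inhibition, read by MTT assay, with a stated time of 48 h (on this read-out higher numbers stand for weaker inhibition and lower numbers for stronger inhibition), gives 2090 nM. Compound 2 `CC(=O)Nc1n[nH]c2cc(-c3cn([C@@H]4CN[C@H](C(=O)Nc5ccc(Br)cc5)C4)nn3)ccc12` in this assay gives 3830 nM. The change between them is 4-bromophenyl in place of 2,4-dichlorophenyl on an amide-type nitrogen, and it made the step of a 1.8-fold higher number from compound 1 to compound 2 (0.26 log units; within the scatter).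

Compound 3 `CC(C)(C)OC(=O)N1C[C@@H](n2cc(-c3ccc4nc(N)sc4n3)nn2)C[C@H]1C(=O)Nc1ccc(Cl)cc1Cl`, built on a different core, in this assay gives 8940 nM. How the cores of compound 1 and compound 3 differ is not broken down here. Compound 4 `CC(C)(C)OC(=O)N1C[C@@H](n2cc(-c3ccc4nc(N)sc4n3)nn2)C[C@H]1C(=O)Nc1ccc(Br)cc1`, still unmeasured, differs from compound 3 by 4-bromophenyl in place of 2,4-dichlorophenyl on an amide-type nitrogen, the same change as before and at the same kind of place, an amide-type nitrogen whose other neighbour is a carbonyl carbon.

Because the first pair moved by a 1.8-fold higher number from compound 1 to compound 2 (0.26 log units; within the scatter), compound 4 is expected to sit close to compound 3, with an estimated step of a 1.5-fold higher number from compound 3 to compound 4 (0.16 log units; within the scatter). On that basis compound 4 is estimated at 13000 nM, expected to fall between 6000 nM and 30000 nM. The measurement itself follows.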

Compound 4, half-maximal inhibitory concentration: 29200 nM
Estimate against measurement, compound 4: 2.2-fold (0.35 log units) below; the measured number falls inside the stated range.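

In this assay, the same swap on the second core gives a 3.3-fold higher number from compound 3 to compound 4 (0.51 log units; beyond the scatter), and the two cores can be compared directly: the same change on two cores in this assay, a 1.8-fold higher number (0.26 log units; within the scatter) from compound 1 to compound 2 and a 3.3-fold higher number (0.51 log units; beyond the scatter) from compound 3 to compound 4, 1.8-fold (0.25 log units) apart, within the scatter of two such steps

The two steps therefore cannot be told apart, and on this evidence the change carries over from the core of compound 1 to the core of compound 3 with a similar size of effect. Among these compounds, this does not show that the steps are truly equal, as only the step on the core of compound 3 is beyond the scatter, and two cores cannot establish a rule for the whole series.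

The compounds shown leave open which part of the swap matters. The groups that leave and enter differ in both their halogen and the number of halogen atoms, so a phenyl ring carrying a single chlorine would help to separate the two. Also open, as far as these compounds go, is how the two cores respond to aryl groups of another kind, such as plain phenyl or a phenyl ring bearing a methoxy group.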